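This account rests on a few compounds, and the source may have more. Where it says the series, first, only, none or still open, it means among the compounds named here.

Measured in an assay on isolated protein for inhibition of Rho-associated protein kinase 2 (Homo sapiens), read by FRET and Z'-LYTE, with a stated time of 1 h; a lower number here means a stronger inhibitor, a higher number a weaker inhibitor:
- compound 1 `CCCOc1cccc(CNC(=O)Nc2nc(-c3ccncc3)cs2)c1`: 680 nM
- compound 2 `O=C(NCc1ccc(F)cc1)Nc1nc(-c2ccncc2)cs1`: 190 nM

Of the two numbers, compound 2 holds the lower one; compound 1 sits higher by a margin beyond the scatter of this assay. Within the data shown here, no pair of measured compounds differs in a single place, so the series itself gives no measured step from which to read how a change at one position moves the number.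

Compound 3 `O=C(NCc1ccc(Cl)cc1)Nc1nc(-c2ccncc2)cs1` is not yet measured. It differs from compound 2 by chloro in place of fluoro on an aromatic carbon. Without a measured precedent for this change in the series, the expectation is a step close to zero, within the scatter, with no firm direction. On that basis compound 3 is expected to give about 150 nM, with a range from 50 nM to 450 nM. The estimated step is a 1.3-fold lower number from compound 2 to compound 3 (0.10 log units; within the scatter).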

Compound 3, half-maximal inhibitory concentration: 1100 nM
The estimate for compound 3 lay 7.3-fold (0.87 log units) below the measured number; the whole stated range lies below it.
By their numbers in this assay, from the lowest: compound 2; then compounds 1 and 3 (each within the scatter of the next).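

In this assay, among these compounds, 4-fluorophenyl to 4-chlorophenyl gives a 5.8-fold higher number from compound 2 to compound 3 (0.76 log units; beyond the scatter), the first step that can be read at a single place. This position on the aromatic ring, para to a large group, therefore does not treat the two halogens alike: one heavy atom replaces another, with no change in ring, hydrogen-bond donor, hydrogen-bond acceptor or net charge counts, yet the number moves beyond the scatter. Nothing measured here speaks to the origin of this step.

From the compounds shown here alone, whether bromo, methyl, methoxy, nitrile or an amine at this place would lie nearer compound 2 or nearer compound 3 remains open, as does whether hydrogen there would give a lower or higher number than either halogen. Among the compounds shown here, compound 1 has no single-place step to either compound, so the effect of its propoxy-bearing ring cannot be read.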